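Replacing cyclohexyl with 3-cyanophenyl: an expected cytotoxicity outcome

The compounds below may be only part of what the source reports. "The series", "measured", "known", "first", "only" and "open" are said of these compounds alone.

Measured so far:
- Compound 1, `COc1ccc(-c2noc(NC(=O)c3ccc(F)cc3)c2C)cc1`: > 100000 nM
- Compound 2, `COc1ccc(-c2cnc(NC(=O)C3CCCCC3)n2C)cc1`: > 100000 nM
- Compound 3, `COc1cccc(-c2cnc(NC(=O)c3ccc(F)cc3)n2C)c1`: > 100000 nM

The three measured compounds were tested in a toxicity assay on THP-1 cells (Homo sapiens) for inhibition; on this read-out higher numbers stand for lower toxicity in this test and lower numbers for higher toxicity in this test. Compound 1 reaches only the limit of the assay, > 100000 nM, and not a number. The same holds for compound 3, whose result of > 100000 nM is a limit of the assay. Compound 2 likewise gives > 100000 nM, which is a limit of the assay rather than a measured number, so all that is known of compound 2 in this assay is that its toxicity lies at or beyond the edge of what the test can resolve. This is summarised by the limit of > 100000 nM in this assay, at which 3 of the 3 values shown sit.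

Among the compounds with values here, no pair of measured compounds differs in only one place, so no measured step is available to guide the next change. Compound 4, `COc1ccc(-c2cnc(NC(=O)c3cccc(C#N)c3)n2C)cc1`, differs from compound 2 in one place: 3-cyanophenyl in place of cyclohexyl on a carbonyl carbon. Given that every measured compound sits at the limit, the step from compound 2 to compound 4 is expected to be none beyond the scatter, a step that the limit leaves unreadable from compound 2 to compound 4. Compound 4 is therefore expected to reach the limit as well, with an estimate of 150000 nM and a likely range from 60000 nM to 400000 nM.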

Compound 4, half-maximal cytotoxic concentration: > 100000 nM
Compound 4 ended at the assay's limit; the forecaster's own chance of this, stated with the estimate: 85%; the middle value does not contradict the limit.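

Compound 2 and compound 4 both end at a limit of the assay rather than at a number, so no step can be read for 3-cyanophenyl in place of cyclohexyl: the limit of > 100000 nM in this assay, at which 4 of the 4 values shown sit. The compounds shown leave open whether any of them truly differ from one another in this assay, and which structural change, if any, would give a readable value.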